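From 1-methoxyethyl to 2H-tetrazol-5-yl on a shared core

The compounds below may be only part of what the source reports. "The series", "measured", "known", "first", "only" and "open" are said of these compounds alone.

Of the compounds shown here, three with the same core have been measured in a functional assay for inhibition, with Homo sapiens as the target; on this read-out higher numbers stand for weaker inhibition and lower numbers for stronger inhibition. Compound 1 `CC(C)(O)c1cc(-c2ccccc2)c2ccc(OCc3cccc(C4(O)CCOCC4)c3)cc2c1` gives 59 nM, compound 2 `COC(C)c1cc(-c2ccccc2)c2ccc(OCc3cccc(C4(O)CCOCC4)c3)cc2c1` gives 41 nM, and compound 3 `CC(=O)c1cc(-c2ccccc2)c2ccc(OCc3cccc(C4(O)CCOCC4)c3)cc2c1` gives 2 nM. Compound 2 therefore sits level with compound 1, as a 1.4-fold lower number from compound 1 to compound 2 (0.16 log units; within the scatter) shows, while a 21-fold lower number from compound 2 to compound 3 (1.31 log units; beyond the scatter) separates it from compound 3.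

Compound 4 `OC1(c2cccc(COc3ccc4c(-c5ccccc5)cc(-c5nn[nH]n5)cc4c3)c2)CCOCC1` has 2H-tetrazol-5-yl in place of 1-methoxyethyl on an aromatic carbon. All measured steps concern this same place. Besides the small step above, a 30-fold lower number from compound 1 to compound 3 (1.47 log units; beyond the scatter) shows that a change here can matter greatly in this assay. For the measured compounds named here, only the acetyl group gave such a drop, however, and no measured compound carries a ring at this place, so the data give no direction for compound 4. No step beyond the scatter is therefore expected, though with wide uncertainty. The expected change is a 1.4-fold lower number from compound 2 to compound 4 (0.14 log units; within the scatter). Compound 4 is estimated at 30 nM, with an expected range from 6 nM to 150 nM.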

Compound 4, half-maximal inhibitory concentration: > 700 nM
Compound 4: only a limit was reported; the forecaster's own chance of this, stated with the estimate: 5%; middle value at least 23-fold (1.36 log units) from the limit.
By their numbers in this assay, from the lowest: compound 3; then compounds 2 and 1 (each within the scatter of the next). At a limit, above all of these: compound 4.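

In this assay compound 4 is reported only as a limit, not as a number: the limit of > 700 nM in this assay, at which 1 of the 4 values shown sits.

Even so, the steps can be read, and all three are large: an at least 17-fold higher number from compound 2 to compound 4 (1.23 log units; beyond the scatter), an at least 11-fold higher number from compound 1 to compound 4 (1.07 log units; beyond the scatter), and an at least 350-fold higher number from compound 3 to compound 4 (2.54 log units; beyond the scatter). For the compounds shown here, the earlier compounds showed this position giving either a large drop with acetyl or no change beyond the scatter, whereas this result shows that a change here can also push the number sharply upward, and it does so with the only group among the four that carries a ring.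

The compounds shown cannot separate the contribution of the ring itself from that of its nitrogen atoms or its hydrogen-bond donor. As far as these compounds go, how a carboxylic acid, a primary amide or a phenyl ring would behave at this position remains open.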